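Swapping Methyl for Trifluoromethyl on an Acetylated Sugar Enone

A few compounds are considered here, and "the series" means these few. Any claim that something is new, unique, unknown or untested is made for them only; others in the source may bear on it.

Three acetylated sugar enones open this set: compound 1 `CC(=O)OC[C@H]1O[C@@H](CC(=O)/C=C/c2ccc([N+](=O)[O-])s2)[C@H](OC(C)=O)[C@@H](OC(C)=O)[C@@H]1OC(C)=O`, compound 2 `CC(=O)OC[C@H]1O[C@@H](CC(=O)/C=C/c2ccccc2)[C@H](OC(C)=O)[C@@H](OC(C)=O)[C@@H]1OC(C)=O` and compound 3 `CC(=O)OC[C@H]1O[C@@H](CC(=O)/C=C/c2ccc(C)cc2)[C@H](OC(C)=O)[C@@H](OC(C)=O)[C@@H]1OC(C)=O`. In an ADME assay on cells (Epithelial cell, Homo sapiens) for cytotoxicity, read by MTT assay, with a stated time of 24 h (a higher number here means that more compound is tolerated, a lower number that less compound is tolerated), compound 1 is recorded as "not determined" (no result reported), and compound 2 is recorded as "not determined" (no result reported). Compound 3 gives 3.18 nM in this assay; it is the only number shown, so it stands alone with nothing to compare against. Compound 4 `CC(=O)OC[C@H]1O[C@@H](CC(=O)/C=C/c2ccc(C(F)(F)F)cc2)[C@H](OC(C)=O)[C@@H](OC(C)=O)[C@@H]1OC(C)=O` is built from compound 3 by one change: trifluoromethyl in place of methyl on an aromatic carbon. Among the compounds with values here, no step between measured compounds exists here to guide the size of this change. The expected step in this assay is a 1.1-fold lower number from compound 3 to compound 4 (0.06 log units; within the scatter), small and within the usual scatter, in either direction. Compound 4 is therefore estimated to give about 2.8 nM in this assay, between 0.9 nM and 9 nM.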

Compound 4, half-maximal cytotoxic concentration: 103 nM
Compound 4: middle estimate off by 37-fold (1.57 log units), on the low side; measured number above the stated range.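

On the aromatic carbon para to a large group, this swap is far from neutral: trifluoromethyl in place of methyl gives a 32-fold higher number from compound 3 to compound 4 (1.51 log units; beyond the scatter) in this assay and so shows that this position strongly affects how much compound the cells tolerate. Nothing available here explains why such a small exchange has so large an effect. On these data alone, whether other groups at this carbon, such as an amine or a carboxylic acid, would move the number up, down or not at all remains open.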